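The compounds below may be only part of what the source reports. "The series", "measured", "known", "first", "only" and "open" are said of these compounds alone.

Compound 1 `CCCCc1cc(C(C)=O)c(O)cc1OCCCCC#N` was examined in an assay on isolated protein for inhibition of leukotriene B4 receptor 1 (Homo sapiens), tested at 10 uM (a lower number here means less inhibition, a higher number more inhibition at the concentration tested (going by the name of the read-out)), where compound 1 gives 41%. Of the two numbers shown, this is the smaller, but the neighbouring compound 2 `COCc1cc(C(C)=O)c(O)cc1OCCCCCCC#N`, which in this assay gives 47%, lies within the usual scatter of it, so the two cannot be separated. Among the compounds with values here, no pair of measured compounds differing in a single place is available, so no measured step guides the next move. The unmeasured compound 3 `CC(=O)c1cc(C(C)=O)c(OCCCCC#N)cc1O` departs from compound 1 in one way: acetyl in place of butyl on an aromatic carbon. With nothing in the measured pair to suggest that this exchange moves the read-out, the expectation is a step in this assay of no size beyond the scatter, in either direction. The estimate for compound 3 is therefore 40%, with a range from 20% to 60%, which is expected to amount to a number 1 percentage points lower from compound 1 to compound 3 (within the scatter).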

Compound 3, a percentage reported as inhibition, at one concentration (the size of the read-out at that concentration, not a potency): 8%
Beside the measured number, compound 3's estimate is 32 percentage points above it; the whole stated range lies above it.
By their numbers in this assay, from the lowest: compound 3; then compounds 1 and 2 (each within the scatter of the next).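

Within the data shown here, replacing butyl with acetyl on this aromatic carbon, ortho to a 4-cyanobutoxy group and para to a hydroxy group, gives the first single-place comparison in this assay, and it produces a number 33 percentage points lower from compound 1 to compound 3 (beyond the scatter). Among these compounds, the substituent at this position therefore has a clear bearing on the read-out, which the earlier compounds could not show, and acetyl does not serve as a replacement for butyl here. No measurement shown bears on why the inhibition falls.

The compounds shown do not separate the loss of butyl from the entry of acetyl, since only this one exchange at this carbon can be read. Going by these compounds, it remains open whether a longer chain such as hexyl would match or exceed compound 1, or whether an amine or a carboxylic acid would behave like acetyl.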